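This account rests on a few compounds, and the source may have more. Where it says the series, first, only, none or still open, it means among the compounds named here.

In an assay (Rattus norvegicus) for inhibition of Fatty-acid amide hydrolase 1 (Homo sapiens) (a lower number here means a stronger inhibitor, a higher number a weaker inhibitor), compound 1 `NC(=O)c1ccc(-c2cnc(C(=O)CCCCCCc3ccccc3)o2)nc1` gives 1.2 nM, while compound 2 `O=C(CCCCCCc1ccccc1)c1ncc(C(=O)N2CCOCC2)o1` gives 24 nM. Among the measured compounds shown here, the only step measured so far, a 20-fold higher number from compound 1 to compound 2 (1.30 log units; beyond the scatter), shows that swapping one large group for another at this position matters a great deal. Compound 2 thus stands at the highest of the two numbers seen, with compound 1 below it by that same step.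

Compound 3 `CSc1cnc(C(=O)CCCCCCc2ccccc2)o1` carries a far smaller group at the same place: methylsulfanyl in place of (morpholin-4-yl)carbonyl on an aromatic carbon. For the measured compounds named here, no measured pair tells what happens when the group at this position shrinks so much; the step from compound 1 to compound 2 only shows that this position is sensitive. With that uncertainty, compound 3 is expected to be a weaker inhibitor than compound 2, a step of an 8.3-fold higher number from compound 2 to compound 3 (0.92 log units; beyond the scatter). The estimate for compound 3 in this assay is 200 nM, within a range from 40 nM to 1500 nM.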

Compound 3, inhibition constant: 25 nM
The estimate for compound 3 lay 8.0-fold (0.90 log units) above the measured number, and the stated range ends above it.
By their numbers in this assay, from the lowest: compound 1; then compounds 2 and 3 (each within the scatter of the next).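

In this assay, methylsulfanyl in place of (morpholin-4-yl)carbonyl gives a 1.0-fold higher number from compound 2 to compound 3 (0.02 log units; within the scatter) and so leaves the number unchanged within the scatter, even though the entering group has 2 heavy atoms and no ring, while the leaving group has 8 heavy atoms and a ring. This position therefore does not respond to every change of group, and these two very different groups cannot be told apart here, whereas 5-carbamoylpyridin-2-yl stands apart, with a 21-fold higher number from compound 1 to compound 3 (1.32 log units; beyond the scatter) as a large step. No measurement on hand explains either the match or the gap.

Going by these compounds, it remains open whether the low number of compound 1 depends on its ring or on its carbamoyl part. A plain pyridin-2-yl group would separate the two, and a carboxylic acid or an amine at this place would show whether other groups fall with compound 1 or with compound 3.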